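A few compounds are considered here, and "the series" means these few. Any claim that something is new, unique, unknown or untested is made for them only; others in the source may bear on it.

Measured so far in a functional assay on A549 cells (Homo sapiens) for antiproliferative activity, read by MTT assay, with a stated time of 48 h; a higher number here means a weaker inhibitor, a lower number a stronger inhibitor:
- Compound 1 `Cn1cc(-c2cnc3ccnc(NC(=O)c4ccc(F)cc4)c3c2)cn1`: > 50000 nM, a limit
- Compound 2 `COc1ccc(C(=O)Nc2nccc3ncc(-c4cnn(C)c4)cc23)cc1`: > 50000 nM, a limit
- Compound 3 `Cn1cc(-c2cnc3ccnc(NC(=O)c4cccnc4)c3c2)cn1`: > 50000 nM, a limit

The series stands at the limit of > 50000 nM in this assay, at which 3 of the 3 values shown sit. Compound 3 therefore offers a limit and no number.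

Compound 4 `Cn1cc(-c2cnc3ccnc(NS(=O)(=O)c4cccs4)c3c2)cn1` differs from compound 3 by (thiophen-2-yl)sulfonyl in place of (pyridin-3-yl)carbonyl on a nitrogen on an aromatic ring.

Going by the values given here, three measured steps touch the group on the carbonyl carbon or its aromatic substituent: a step that the two limits leave unreadable from compound 1 to compound 2, a step that the two limits leave unreadable from compound 1 to compound 3 and a step that the two limits leave unreadable from compound 2 to compound 3. None has a readable size, and none replaces the carbonyl with a sulfonyl. A clear step in this assay is not expected, and another limit is the likeliest report.

The expected change is an at least 1.1-fold lower number from compound 3 to compound 4 (0.04 log units; that floor lies within the scatter).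

For compound 4 the estimated value is 45000 nM, with an expected range of 10000 nM to 80000 nM.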

Compound 4, half-maximal inhibitory concentration: 9400 nM
Estimate against measurement, compound 4: 4.8-fold (0.68 log units) above; measured number outside the range, below it.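

In this assay, (thiophen-2-yl)sulfonyl in place of (pyridin-3-yl)carbonyl on this nitrogen gives an at least 5.3-fold lower number from compound 3 to compound 4 (0.72 log units; beyond the scatter), so a change at this position can move the read-out. The earlier steps shown here among the carbonyl compounds cannot be read, and they gave no size for any change. Compound 4 is the only compound shown with a number rather than a limit: the limit of > 50000 nM in this assay, at which 3 of the 4 values shown sit.

The sulfonyl and the thiophene enter together in this one step, and their shares remain unseparated. From the compounds shown here alone, whether a thiophen-2-yl on the carbonyl or a phenyl on the sulfonyl would give a measurable number remains open.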